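Oxolane ether in place of the fluorophenethyl chain

The source may hold more compounds than are shown below. What is called first, only, known or untested is meant among the compounds shown, and "the series" means these compounds.

Compound 2 `Cc1nc(C)c([C@H](OC(C)(C)C)C(=O)O)c(N2CCC(C)(C)CC2)c1-c1ccc(OCCc2cc(F)c(F)cc2F)cc1` stands at the top of the pair measured so far: in an ADME assay on microsomes from liver (Homo sapiens) for metabolic stability, read by LC-MS, tested at 0.5 uM (on this read-out higher numbers stand for a longer-lived compound and lower numbers for a shorter-lived compound), compound 2 gives > 2 h, which is a limit of the assay and not a number (the limit of > 2 h in this assay, at which 1 of the 2 values shown sits). Compound 1 `Cc1nc(C)c([C@H](OC(C)(C)C)C(=O)O)c(N2CCC(C)(C)CC2)c1-c1ccc(OCCc2ccc(F)cc2F)cc1` carries hydrogen where compound 2 carries fluorine; in this assay compound 1 gives 1.08 h. For the measured compounds named here, the one measured step, an at least 1.8-fold higher number from compound 1 to compound 2 (0.26 log units; that floor lies within the scatter), is therefore a floor on a change that runs into the limit.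

Compound 3 `Cc1nc(C)c([C@H](OC(C)(C)C)C(=O)O)c(N2CCC(C)(C)CC2)c1-c1ccc(OC2COCC2c2ccc(F)cc2)cc1` differs from compound 2 at the ether oxygen: 4-(4-fluorophenyl)oxolan-3-yl in place of 2-(2,4,5-trifluorophenyl)ethyl on an oxygen on an aromatic ring. Going by the values given here, no measured step touches this exchange; the only step known, an at least 1.8-fold higher number from compound 1 to compound 2 (0.26 log units; that floor lies within the scatter), concerns a single fluorine on the aromatic ring and says nothing about replacing the whole 2-(2,4,5-trifluorophenyl)ethyl chain by 4-(4-fluorophenyl)oxolan-3-yl. The replacement removes two of the three fluorines and brings in a five-membered non-aromatic ring with one oxygen, so the expectation for compound 3 is kept close to the range spanned by compound 1 and compound 2, with wide bounds. Compound 3 is expected at 1.5 h, between 0.6 h and 4 h, a step of an at least 1.3-fold lower number from compound 2 to compound 3 (0.12 log units; that floor lies within the scatter) that is itself uncertain because the value of compound 2 is only a limit.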

Compound 3, half-life: 0.783 h
The estimate for compound 3 lay 1.9-fold (0.28 log units) above the measured number; low and high end bracket the measured number.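

Set on an oxygen on an aromatic ring, 4-(4-fluorophenyl)oxolan-3-yl in place of 2-(2,4,5-trifluorophenyl)ethyl gives in this assay an at least 2.5-fold lower number from compound 2 to compound 3 (0.40 log units; beyond the scatter), so this position accepts a ring-bearing ether but the exchange has a cost against the trifluorophenyl chain. Against the chain of compound 1, the same group gives a 1.4-fold lower number from compound 1 to compound 3 (0.14 log units; within the scatter), so on this read-out the oxolane ether cannot be told apart from 2-(2,4-difluorophenyl)ethyl, and the loss shows only against the chain of compound 2. The value of compound 2, > 2 h, is a limit of the assay and not a number: the limit of > 2 h in this assay, at which 1 of the 3 values shown sits.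

The compounds shown do not separate the oxolane ring from the fluorines on the phenyl ring, as both change together in compound 3. Still open, on these data alone, is how 4-(2,4,5-trifluorophenyl)oxolan-3-yl on the same oxygen, or an amine in place of the ring oxygen of the oxolane, would read in this assay.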